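A carboxy swap on a compound at the assay limit

The compounds below may be only part of what the source reports. "The series", "measured", "known", "first", "only" and "open" are said of these compounds alone.

Compound 1 `CCN(CC)c1ccc(-c2cccc(Cl)c2)nn1`: > 25000 nM
Compound 2 `CCN(CC)c1ccc(-c2cccc(C(F)(F)F)c2)nn1`: > 25000 nM
Compound 3 `CCN(CC)c1ccc(-c2ccc(C#N)cc2)nn1`: > 25000 nM

In a functional assay on Huh-7 cells (Homo sapiens) for antiproliferative activity, with a stated time of 48 h (a lower number here means a stronger inhibitor, a higher number a weaker inhibitor), compound 3 gives > 25000 nM, which is a limit and not a number. It shares that position with the other two compounds, as the limit of > 25000 nM in this assay, at which 3 of the 3 values shown sit, shows, so compound 3 offers no measured potency to start from.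

Compound 4 `CCN(CC)c1ccc(-c2ccc(C(=O)O)cc2)nn1` differs from compound 3 in one place: carboxy in place of cyano on an aromatic carbon. Carboxy takes the place of cyano on an aromatic carbon, para to a large group.

Within the data shown here, the only measured step is a step that the two limits leave unreadable from compound 1 to compound 2. It involves a different exchange of groups and has no readable size, so it gives no size to carry over. None of the three compounds has a measured value in this assay, so compound 4 is expected to stay weak, with no readable gain. The expected result is a step that the limit leaves unreadable from compound 3 to compound 4, and another limit is the likeliest report. For compound 4 the estimated value is 30000 nM, with an expected range of 15000 nM to 100000 nM.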

Compound 4, half-maximal inhibitory concentration: > 25000 nM
Compound 4: a limit, no number; the forecaster's own chance of this, stated with the estimate: 85%; the middle value is on the limit's open side.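

Compound 4 also gives a limit and not a number, so the swap of cyano for carboxy from compound 3 to compound 4 has no readable size: the limit of > 25000 nM in this assay, at which 4 of the 4 values shown sit. On these data alone, whether any change to the shared core brings a measurable value in this assay stays open.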